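The source may report more compounds than this note shows. Statements on the series, on what has been measured and on what is new or still open speak of the compounds shown alone.

Measured so far:
compound 1, `O=C(Nc1cccc(-n2cc(-c3ccncc3)c(-c3ccc(Cl)c(O)c3)n2)c1)Nc1cccc(C(F)(F)F)c1`: 13800 nM
compound 2, `COc1cc(-c2nn(-c3cccc(NC(=O)Nc4cc(C(F)(F)F)cc(C(F)(F)F)c4)c3)cc2-c2ccncc2)ccc1Cl`: 2670 nM
compound 3, `COc1cc(-c2nn(-c3cccc(NC(=O)c4cccc(C(F)(F)F)c4)c3)cc2-c2ccncc2)ccc1Cl`: 40600 nM

In a functional assay on SK-MEL-5 cells (Homo sapiens) for inhibition, read by sulforhodamine B assay, with a stated time of 48 h (a higher number here means that more compound is tolerated, a lower number that less compound is tolerated), compound 3 gives 40600 nM, the highest number of the three; compound 1 comes nearest with 13800 nM and compound 2 lies furthest with 2670 nM, both gaps beyond the scatter. Compound 4, `COc1cc(-c2nn(-c3cccc(NC(=O)Nc4ccc(Cl)c(Cl)c4)c3)cc2-c2ccncc2)ccc1Cl`, has not yet been measured in this assay. It differs from compound 3 in one place: (3,4-dichlorophenyl)amino in place of 3-(trifluoromethyl)phenyl on a carbonyl carbon. Compounds 1 and 2 both carry an amino group on the corresponding carbonyl carbon and both sit at lower numbers than compound 3, so a downward step is expected here, with no sound basis for a finer prediction. Compound 4 is therefore expected to give about 6000 nM, within a range of 1500 nM to 25000 nM. The step from compound 3 expected from this estimate is a 6.8-fold lower number from compound 3 to compound 4 (0.83 log units; beyond the scatter).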

Compound 4, concentration lethal to 50% of the cells: 3020 nM
Estimate against measurement, compound 4: 2.0-fold (0.30 log units) above, and the stated range covers the measured number.
By their numbers in this assay, from the lowest: compounds 2 and 4 (each within the scatter of the next); then compound 1; then compound 3.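

Placing (3,4-dichlorophenyl)amino in place of 3-(trifluoromethyl)phenyl on the carbonyl carbon gives, in this assay, a 13-fold lower number from compound 3 to compound 4 (1.13 log units; beyond the scatter). Among the compounds shown here, this single change shows that this position alone can move the number by a large step, whereas the earlier compounds differed from one another in more than one place. Nothing shown gives a cause for this step.

The compounds shown leave open whether the step follows the amino nitrogen or the chlorines on the ring. They also leave open what a methylene or an oxygen in place of that nitrogen would give.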